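A few compounds are considered here, and "the series" means these few. Any claim that something is new, unique, unknown or untested is made for them only; others in the source may bear on it.

Compound 2 `C#CCNC(=O)/C(C)=C(\C)c1ccc(Cl)cc1` gives 60 mg/kg in a toxicity assay on the whole organism (strain Icem-CET (SPF Caw)) for cytotoxicity, with Mus musculus as the target (on this read-out lower numbers stand for an effect already at smaller amounts and higher numbers for an effect only at larger amounts of compound), the lowest number of the three, though only the gap to compound 1 is beyond the scatter. Compound 3 `C#CCNC(=O)/C(C)=C(\C)c1ccc(C)cc1` gives 120 mg/kg in this assay, and a 2.0-fold higher number from compound 2 to compound 3 (0.30 log units; within the scatter). Compound 1 `C#CCNC(=O)/C(C)=C(\C)c1ccc(OC)cc1` gives 150 mg/kg in this assay; a 2.5-fold lower number from compound 1 to compound 2 (0.40 log units; beyond the scatter), while a 1.3-fold lower number from compound 1 to compound 3 (0.10 log units; within the scatter). Compound 4 `C=CCNC(=O)/C(C)=C(\C)c1ccc(Cl)cc1` differs from compound 2 by vinyl in place of ethynyl on a saturated chain carbon bound to an amide-type nitrogen. Going by the values given here, all three measured steps concern the substituent on the aromatic carbon; none touches the chain on the amide-type nitrogen, so no measured step bears on this change. In this assay the expected step is therefore no change at the digits printed from compound 2 to compound 4 (within the scatter), not beyond the scatter. The estimate for compound 4 in this assay is 60 mg/kg, expected to lie between 30 mg/kg and 120 mg/kg.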

Compound 4, dose for half-maximal effect: 70 mg/kg
Beside the measured number, compound 4's estimate is 1.2-fold (0.07 log units) below it; measured number inside the range.
By their numbers in this assay, from the lowest: compounds 2, 4, 3 and 1 (each within the scatter of the next, the first and the last beyond it).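

Within this assay the chain on the amide-type nitrogen now has a measured step, with a 1.2-fold higher number from compound 2 to compound 4 (0.07 log units; within the scatter) as its only reading. With chloro on the aromatic carbon, the triple bond of the propargyl group is therefore not needed for a number of this size, and the allyl group serves equally within the scatter. No measurement at hand gives a reason for this result.

On these data alone, whether the same change reads alike with methoxy or methyl on the aromatic carbon stays open. So does the effect of a saturated propyl chain or a longer chain on that nitrogen.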